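Trimethoxyphenyl isoxazole amides: weak cytotoxicity throughout

The source may report more compounds than this note shows. Statements on the series, on what has been measured and on what is new or still open speak of the compounds shown alone.

Compound 1 `COc1ccc(-c2c(-c3cc(OC)c(OC)c(OC)c3)noc2NC(C)=O)cc1OC` is the reference point of the set. In a functional assay on SMMC-7721 cells (Homo sapiens) for cytotoxicity, read by MTT assay, with a stated time of 48 h (on this read-out higher numbers stand for weaker inhibition and lower numbers for stronger inhibition), compound 1 gives 46300 nM. Compound 2 `COc1cc(-c2noc(NC(C)=O)c2-c2ccc(Cl)cc2)cc(OC)c1OC` differs from it by 4-chlorophenyl in place of 3,4-dimethoxyphenyl on an aromatic carbon. For compound 2 this assay reports only a limit, > 50000 nM. Compound 3 `COc1ccc(-c2c(-c3cc(OC)c(OC)c(OC)c3)noc2N(C(C)=O)C(C)=O)cc1OC` differs from compound 1 by acetyl in place of hydrogen on an amide-type nitrogen, which is the whole difference between the two cores of this set. For compound 3 this assay likewise reports only a limit, > 50000 nM. The measured steps are an at least 1.0-fold higher number from compound 1 to compound 2 (0.03 log units; that floor lies within the scatter) and an at least 1.0-fold higher number from compound 1 to compound 3 (0.03 log units; that floor lies within the scatter); both are floors rather than numbers, since (the limit of > 50000 nM in this assay, at which 2 of the 3 values shown sit).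

Compound 4 `COc1cc(-c2noc(N(C(C)=O)C(C)=O)c2-c2ccc(Cl)cc2)cc(OC)c1OC` has not been measured. It differs from compound 3 by 4-chlorophenyl in place of 3,4-dimethoxyphenyl on an aromatic carbon. Among the compounds with values here, this is the same kind of change as the one from compound 1 to compound 2, not the same: around the place, the ring atom next to it bears a diacetylamino group (7 heavy atoms) in compound 3, where in compound 1 it bears an acetamido group (4 heavy atoms).

With compound 3 already at the limit and the earlier change of this kind giving an at least 1.0-fold higher number from compound 1 to compound 2 (0.03 log units; that floor lies within the scatter), compound 4 is expected to stay at or beyond the limit, and this assay is expected to report a limit rather than a number for it. The expected step is a step that the limit leaves unreadable from compound 3 to compound 4. The estimate for compound 4 in this assay is 80000 nM, with a range from 40000 nM to 200000 nM.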

Compound 4, half-maximal inhibitory concentration: > 50000 nM
Compound 4 gave a limit, no number; the forecaster's own chance of this, stated with the estimate: 85%; the middle value is on the limit's open side.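

In this assay compound 4 gives > 50000 nM, which is a limit and not a number. No new step can be read from compound 2 or compound 3 to compound 4, because each pair has a limit on both sides: the limit of > 50000 nM in this assay, at which 3 of the 4 values shown sit.

The compounds shown leave open the actual values of compound 2, compound 3 and compound 4, and so the size of either change within this set.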